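This account rests on a few compounds, and the source may have more. Where it says the series, first, only, none or still open, it means among the compounds named here.

Compound 1 `O=C(Nc1ncc(Cc2ccc(Cl)cc2)s1)c1cccs1` gives > 50000 nM in an ADME assay on HepG2 2.2.15 cells (Homo sapiens) for cytotoxicity; on this read-out higher numbers stand for lower toxicity in this test and lower numbers for higher toxicity in this test. Compound 2 `O=C(Nc1ncc(Cc2ccc(Br)cc2)s1)c1cccs1` gives > 50000 nM in this assay. Compound 3 `O=C(Nc1ncc(C(Oc2ccc3cc(Br)ccc3c2)c2ccc(Cl)cc2)s1)c1cccs1` is recorded in this assay only as "not toxic" (no number reported).

The values of compound 1 and of compound 2 are limits of this assay and not numbers. Compound 3 has no number at all; the only record is the word that it is not toxic. Compound 3 therefore stands with the other two at the non-toxic end of what has been seen, without a figure of its own.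

Compound 4 `O=C(Nc1ncc(C(Oc2ccc3cc(Br)ccc3c2)c2ccc(Cl)cc2)s1)c1ccc(F)cc1F` has not yet been measured. It differs from compound 3 in one place: 2,4-difluorophenyl in place of thiophen-2-yl on a carbonyl carbon.

Within the data shown here, the single measured step, a step that the two limits leave unreadable from compound 1 to compound 2, cannot be read because both of its ends sit at the limit of > 50000 nM in this assay, at which 2 of the 3 values shown sit. Among the measured compounds shown here, no measured step touches the carbonyl carbon or the thiophen-2-yl that leaves, so nothing seen bears directly on the change from compound 3 to compound 4. With all three measured compounds showing no toxicity within the window of this assay, no movement beyond the scatter is expected for compound 4. Compound 4 is estimated at 50000 nM in this assay, between 20000 nM and 100000 nM, and most probably will again be reported as a limit rather than a number.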

Compound 4, half-maximal cytotoxic concentration: "not toxic" (no number reported)
The entry for compound 4 holds no number; there is nothing to compare the estimate with.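

Compound 3 and compound 4 are both recorded in this assay only as "not toxic", without a number, and no step can be read between them. The compounds shown leave open whether 2,4-difluorophenyl in place of thiophen-2-yl on the carbonyl carbon shifts the half-maximal cytotoxic concentration at all, and at what concentration any of these compounds would become toxic.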